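The source may hold more compounds than are shown below. What is called first, only, known or untested is meant among the compounds shown, and "the series" means these compounds.

Compound 1 `O=C(Nc1ccc(Oc2ccnc3[nH]ccc23)cc1)c1cc2cccnc2n(-c2ccccc2)c1=O`: 380 nM
Compound 2 `O=C(Nc1ccc(Oc2ccnc3[nH]ccc23)cc1)c1cc2cccnc2n(-c2ccc(Br)cc2)c1=O`: "not determined" (no result reported)

In a functional assay on NCI-H460 cells (Homo sapiens) for antiproliferative activity, read by MTT assay, with a stated time of 72 h (on this read-out higher numbers stand for weaker inhibition and lower numbers for stronger inhibition), compound 1 gives 380 nM. Compound 2 was taken into the same series, but in this assay compound 2 gives "not determined" (no result reported), so no number stands beside it. Among the compounds with values here, compound 1 is therefore the only compound of the two with a measured result, and nothing can be said about any step between the two; the data hold no pair of measured compounds that differ in a single place.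

Compound 3 `Cn1ccc2c(Oc3ccc(NC(=O)c4cc5cccnc5n(-c5ccccc5)c4=O)cc3)ccnc21` is the next compound to be measured. It differs from compound 1 by methyl in place of hydrogen on an aromatic nitrogen, that is, a methyl in place of hydrogen on an aromatic nitrogen of the fused five-membered ring of the shared core. Within the data shown here, no measured pair shows what such an exchange does in this assay, so the expectation rests on compound 1 alone. The step from compound 1 to compound 3 is expected to lie beyond the scatter and to go toward weaker inhibition, with a 3.9-fold higher number from compound 1 to compound 3 (0.60 log units; beyond the scatter). Compound 3 is estimated at 1500 nM, within a range from 400 nM to 6000 nM.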

Compound 3, half-maximal inhibitory concentration: 560 nM
Estimate against measurement, compound 3: 2.7-fold (0.43 log units) above; the range from low to high includes it.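

In this assay the methyl in place of hydrogen on an aromatic nitrogen of the five-membered aromatic ring gives a 1.5-fold higher number from compound 1 to compound 3 (0.17 log units; within the scatter), so the exchange leaves no difference that can be told apart from the usual scatter of repeated measurements. Within the data shown here, this is the first measured pair, and it shows that, on the shared core of compound 1, a hydrogen on this nitrogen is not required for antiproliferative activity at this level, since compound 3 carries a methyl there and its number stays within the scatter of that of compound 1. No further information bears on this result.

The compounds shown leave open how much room this nitrogen allows, whether a longer chain such as ethyl or propyl, or a chain ending in an amine or a carboxylic acid, would read as the methyl does. They also leave open whether this single pair holds when other parts of the shared core carry a different group, such as a fluorine or a methoxy group.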